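Bromo for Methyl on the Thiophene of Compound 3

The source may report more compounds than this note shows. Statements on the series, on what has been measured and on what is new or still open speak of the compounds shown alone.

Compound 3 `Cc1ccc(CN[C@@H]2C[C@H]3C[C@@H]([C@H]2C)C3(C)C)s1` gives 780 nM in an ADME assay on MDCK cells (Canis lupus familiaris) for cytotoxicity, read by microscopy, with a stated time of 48 h (a lower number here means that less compound is tolerated, a higher number that more compound is tolerated), the lowest of the two numbers available. Compound 1 `CSc1ccc(CN[C@@H]2C[C@H]3C[C@@H]([C@H]2C)C3(C)C)s1` gives 25000 nM in this assay, and the step of a 32-fold lower number from compound 1 to compound 3 (1.51 log units; beyond the scatter) alters the same aromatic carbon. Compound 2 `C[C@H]1[C@H](NCc2cncs2)C[C@H]2C[C@@H]1C2(C)C` returns only a limit, > 100000 nM, in this assay. The step of an at least 120-fold lower number from compound 2 to compound 3 (2.10 log units; beyond the scatter) exchanges the whole ring and bears less on what follows. Compound 4 `C[C@H]1[C@H](NCc2ccc(Br)s2)C[C@H]2C[C@@H]1C2(C)C` differs from compound 3 by bromo in place of methyl on an aromatic carbon. Because compound 1 gives 25000 nM with methylsulfanyl on that carbon, a bromo there is expected to move the number upward again, and the step is estimated as the smaller 3.8-fold higher number from compound 3 to compound 4 (0.59 log units; beyond the scatter). Compound 4 is therefore estimated at 3000 nM, between 780 nM and 12500 nM.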

Compound 4, minimum cytotoxic concentration: 43000 nM
Beside the measured number, compound 4's estimate is 14-fold (1.16 log units) below it, and the stated range ends below it.
By their numbers in this assay, from the lowest: compound 3; then compounds 1 and 4 (each within the scatter of the next). At a limit, above all of these: compound 2.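

The step of a 55-fold higher number from compound 3 to compound 4 (1.74 log units; beyond the scatter) shows that in this assay the low number goes with methyl on this carbon next to the ring sulfur, not with the thiophene as such. Bromo and methylsulfanyl on this carbon cannot be told apart, with a 1.7-fold higher number from compound 1 to compound 4 (0.24 log units; within the scatter). The step of an at least 2.3-fold lower number from compound 2 to compound 4 (0.36 log units; beyond the scatter) is read against a limit for compound 2: the limit of > 100000 nM in this assay, at which 1 of the 4 values shown sits.

On these data alone, whether methyl is alone in giving so low a number remains open. Ethyl, chloro or methoxy on this carbon could show whether the low number extends beyond methyl.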